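Ring size at the thiocarbonyl amine: compound 4

A few compounds are considered here, and "the series" means these few. Any claim that something is new, unique, unknown or untested is made for them only; others in the source may bear on it.

Measured so far in a functional assay on MDA-MB-435S cells (Homo sapiens) for antiproliferative activity, read by MTT assay, with a stated time of 72 h; on this read-out lower numbers stand for stronger inhibition and higher numbers for weaker inhibition:
compound 1 `O=c1c(CSC(=S)N2CCOCC2)coc2ccccc12`: 3900 nM
compound 2 `CN1CCN(C(=S)SCc2coc3ccccc3c2=O)CC1`: 2200 nM
compound 3 `O=c1c(CSC(=S)N2CCCCC2)coc2ccccc12`: 470 nM

Compound 3 stands lowest of the three in this assay; the nearest is compound 2, at a 4.7-fold lower number from compound 2 to compound 3 (0.67 log units; beyond the scatter), and the furthest compound 1, at an 8.3-fold lower number from compound 1 to compound 3 (0.92 log units; beyond the scatter). Compound 1 and compound 2 sit close together, a 1.8-fold lower number from compound 1 to compound 2 (0.25 log units; within the scatter).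

Compound 4 `O=c1c(CSC(=S)N2CCCC2)coc2ccccc12` is the next candidate. pyrrolidin-1-yl in place of piperidin-1-yl on a thiocarbonyl carbon Every measured step swapped one six-membered non-aromatic ring for another of the same size, so none bears directly on a change to a five-membered non-aromatic ring. Lacking such a comparison, compound 4 is expected to sit near compound 3, with a step of a 1.5-fold higher number from compound 3 to compound 4 (0.17 log units; within the scatter). The estimate for compound 4 in this assay is 700 nM, within a range from 250 nM to 2000 nM.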

Compound 4, half-maximal inhibitory concentration: 3800 nM
Compound 4: middle estimate off by 5.4-fold (0.73 log units), on the low side, and the stated range ends below it.
By their numbers in this assay, from the lowest: compound 3; then compounds 2, 4 and 1 (each within the scatter of the next).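

In this assay the piperidin-1-yl result does not carry over to the next smaller ring on the thiocarbonyl carbon: pyrrolidin-1-yl gives an 8.1-fold higher number from compound 3 to compound 4 (0.91 log units; beyond the scatter) and loses the gap that set compound 3 apart. Compound 4 instead groups with the two six-membered rings bearing a second hetero atom, with a 1.7-fold higher number from compound 2 to compound 4 (0.24 log units; within the scatter) and a 1.0-fold lower number from compound 1 to compound 4 (0.01 log units; within the scatter) within the scatter, so a ring with a single hetero atom is not enough to give the low number. No measurement available here accounts for this step.

Open, from the compounds shown here alone, is whether azepan-1-yl, the seven-membered ring, stays near compound 3. Also open, going by these compounds, is how a substituted ring such as 4-methylpiperidin-1-yl behaves at this position.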